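A few compounds are considered here, and "the series" means these few. Any claim that something is new, unique, unknown or untested is made for them only; others in the source may bear on it.

Three compounds share one core and differ only in the group on a saturated ring carbon. Compound 1 `CC(C)(C)C1=NN(c2ccc(Cl)cc2)C(c2ccc(F)cc2)C1` has "not determined" (no result reported) in an assay on U-937 cells for inhibition of protein kinase C zeta type (Homo sapiens), read by reporter gene assay (on this read-out lower numbers stand for stronger inhibition and higher numbers for weaker inhibition), and compound 2 `CC(C)(C)C1=NN(c2ccc(Cl)cc2)C(c2ccc(Cl)cc2)C1` likewise has "not determined" (no result reported) in this assay. Going by the values given here, compound 3 `CC(C)(C)C1=NN(c2ccc(Cl)cc2)C(c2cccc(O)c2)C1` carries a 3-hydroxyphenyl group, and in this assay compound 3 gives 2000 nM, the only number available, so there is nothing to rank it against. Compound 4 `CC(C)(C)C1=NN(c2ccc(Cl)cc2)C(c2ccc(O)c(Cl)c2)C1` differs from compound 3 by 3-chloro-4-hydroxyphenyl in place of 3-hydroxyphenyl on a saturated ring carbon. Among the compounds with values here, with no measured step to lean on, the change is expected to be modest, a 1.3-fold lower number from compound 3 to compound 4 (0.12 log units; within the scatter), staying within the usual scatter, though it could go either way. Compound 4 is therefore estimated at 1500 nM, with a plausible range from 500 nM to 5000 nM.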

Compound 4, half-maximal inhibitory concentration: 2900 nM
Estimate against measurement, compound 4: 1.9-fold (0.29 log units) below; the range from low to high includes it.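

In this assay, going by these compounds alone, placing 3-chloro-4-hydroxyphenyl instead of 3-hydroxyphenyl on the saturated ring carbon gives a 1.5-fold higher number from compound 3 to compound 4 (0.16 log units; within the scatter) and provides the first measured step at this position. That step lies within the usual scatter, so this read-out does not separate the two groups. No available evidence bears on this result. From the compounds shown here alone, it remains open what an amine or a carboxylic acid on the phenyl ring would do here. Going by these compounds, it also remains open whether any group at this position can shift the number beyond the scatter.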